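Working notes: methoxy in place of fluoro, cytotoxicity

A few compounds are considered here, and "the series" means these few. Any claim that something is new, unique, unknown or untested is made for them only; others in the source may bear on it.

Measured so far:
compound 1 `Fc1ccc2nc(-c3cc(-c4ccccc4)n(-c4ccccc4)n3)ccc2c1`: 115%
compound 2 `Fc1ccc(-c2cc(-c3ccc4cc(F)ccc4n3)nn2-c2ccccc2)cc1`: 89.7%

In an ADME assay on Huh-7 cells (Homo sapiens) for cytotoxicity, read by XTT assay, with a stated time of 3 days, tested at 200 uM (a higher number here means a weaker effect of the compound at the concentration tested, a lower number a stronger effect), compound 2 stands lowest of the two numbers; its nearest neighbour is compound 1, and the step of a number 25.3 percentage points lower from compound 1 to compound 2 (beyond the scatter) lies beyond the scatter. Compound 3 `COc1ccc(-c2cc(-c3ccc4cc(F)ccc4n3)nn2-c2ccccc2)cc1` differs from compound 2 by methoxy in place of fluoro on an aromatic carbon. For the measured compounds named here, no measured step swaps one substituent for another at this position; the only step known, fluoro entering in place of hydrogen, bears on it indirectly at best. No step beyond the scatter is therefore expected in this assay for compound 3, which is estimated at 90% within 65% to 115%, an expected step of a number 0.3 percentage points higher from compound 2 to compound 3 (within the scatter).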

Compound 3, a percentage reported as activity, at one concentration (the size of the read-out at that concentration, not a potency): 93.7%
Compound 3: middle estimate off by 3.7 percentage points, on the low side, and the stated range covers the measured number.
By their numbers in this assay, from the lowest: compounds 2 and 3 (each within the scatter of the next); then compound 1.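

In this assay the change from 4-fluorophenyl to 4-methoxyphenyl gives a number 4 percentage points higher from compound 2 to compound 3 (within the scatter) and so does not separate the two groups at this position. Methoxy in place of hydrogen gives a number 21.3 percentage points lower from compound 1 to compound 3 (beyond the scatter) and thus shows that the step away from hydrogen is not confined to fluoro. Nothing at hand explains this behaviour of the position.

Open, as far as these compounds go, is whether an amine or a carboxylic acid here would read with fluoro and methoxy or with hydrogen, and whether the same holds at other positions on the core.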